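Lengthening a Side Chain in a Series at the Limit

This account rests on a few compounds, and the source may have more. Where it says the series, first, only, none or still open, it means among the compounds named here.

Compound 1 `CCOC(=O)c1ccc(-c2nn(C)c3ccccc23)cc1`, compound 2 `CCCn1nc(-c2ccc(C(=O)OCC)cc2)c2ccccc21` and compound 3 `COC(=O)c1ccc(-c2nn(Cc3ccccc3)c3ccccc23)cc1` share a core and were tested in a functional assay on cells (Platelet, Homo sapiens) for inhibition; on this read-out higher numbers stand for weaker inhibition and lower numbers for stronger inhibition. Compound 1 reaches only the limit of the assay, > 10000 nM. Compound 2 likewise gives only a limit, > 10000 nM. Compound 3 also shows only a limit, > 10000 nM. The change from compound 1 to compound 2 is ethyl in place of hydrogen on a saturated chain carbon bound to an aromatic nitrogen, and its step that the two limits leave unreadable from compound 1 to compound 2 cannot be read because of the limit of > 10000 nM in this assay, at which 3 of the 3 values shown sit. Compound 4 `CCCOC(=O)c1ccc(-c2nn(Cc3ccccc3)c3ccccc23)cc1` has not been measured; it differs from compound 3 by ethyl in place of hydrogen on a saturated chain carbon bound to an oxygen next to a carbonyl group, the same kind of change as before, though here on a saturated chain carbon bound to an oxygen next to a carbonyl group rather than to an aromatic nitrogen. The difference between the two cores is not broken down here. Within the data shown here, with every value so far at the limit, a step of a number no higher from compound 3 to compound 4 (the limit leaves the size open) is expected. Compound 4 is therefore estimated at 10000 nM, most likely again only a limit.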

Compound 4, half-maximal inhibitory concentration: > 10000 nM
Compound 4: a limit, no number; the forecaster's own chance of this, stated with the estimate: 85%; the middle value sits exactly at the limit.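

No step can be read between compound 3 and compound 4, because both stop at the same limit: the limit of > 10000 nM in this assay, at which 4 of the 4 values shown sit. The compounds shown leave open how strongly any of them inhibits, and whether a longer chain changes that at all.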